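Swapping the aryl group on the triazole of compound 2

The source may report more compounds than this note shows. Statements on the series, on what has been measured and on what is new or still open speak of the compounds shown alone.

Measured compounds:
compound 1 `CC(C)(C)c1cn(C[C@H](O)[C@H]2OC(=O)C(OCc3ccccc3)=C2OCc2ccccc2)nn1` — 730 nM
compound 2 `COc1ccc(-c2cn(C/C=C3\OC(=O)C(OCc4ccccc4)=C3OCc3ccccc3)nn2)cc1` — 39100 nM

In a functional assay on MCF7 cells (Homo sapiens) for antiproliferative activity, read by MTT assay, with a stated time of 72 h (a lower number here means a stronger inhibitor, a higher number a weaker inhibitor), compound 2 gives 39100 nM, the highest of the two numbers recorded; compound 1 gives 730 nM, a gap well beyond the scatter. Compound 3 `O=C1O/C(=C\Cn2cc(-c3cc(F)cc(F)c3)nn2)C(OCc2ccccc2)=C1OCc1ccccc1` differs from compound 2 in one place: 3,5-difluorophenyl in place of 4-methoxyphenyl on an aromatic carbon. Among the compounds with values here, no measured pair shows this kind of change, so there is no direct guide. The step from compound 2 to compound 3 is expected to be small, a 1.6-fold lower number from compound 2 to compound 3 (0.19 log units; within the scatter), not clearly beyond the scatter. Compound 3 is therefore estimated at 25000 nM, with a range from 6000 nM to 100000 nM.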

Compound 3, half-maximal inhibitory concentration: > 100000 nM
Compound 3: only a limit was reported; the forecaster's own chance of this, stated with the estimate: 15%; at least 4.0-fold (0.60 log units) between middle value and limit.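

In this assay, this carbon of the triazole proved sensitive to the choice of aryl group: 3,5-difluorophenyl in place of 4-methoxyphenyl gives an at least 2.5-fold higher number from compound 2 to compound 3 (0.40 log units; beyond the scatter). The two groups have the same heavy-atom count and one aromatic ring each, yet the step lies beyond the scatter. Compound 3 gives > 100000 nM, which is a limit of the assay and not a number, so the step has a floor but no known size: the limit of > 100000 nM in this assay, at which 1 of the 3 values shown sits.

The compounds shown do not separate the loss of the methoxy group from the gain of the two fluorines. On these data alone, how a phenyl group carrying an amine or a carboxylic acid would read at this position also stays open.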